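Swapping Thiophene for Furan on a Porcupine Inhibitor

The source may report more compounds than this note shows. Statements on the series, on what has been measured and on what is new or still open speak of the compounds shown alone.

Three measured compounds and one unmeasured compound are compared in an assay on L cells for inhibition of Protein-serine O-palmitoleoyltransferase porcupine (Mus musculus), read by reporter gene assay, with a stated time of 24 h; a lower number here means that less compound is needed, a higher number that more compound is needed for the effect. Compound 1 `CCOC(=O)c1ccc2nc(NC(=O)CNC(=O)c3nn(-c4ccccc4)c(=O)c4ccccc34)sc2c1` is recorded only as > 25000 nM, which is a limit of the assay rather than a number (the limit of > 25000 nM in this assay, at which 1 of the 3 values shown sits). Compound 2 `O=C(CSc1nc2c(c(=O)n1-c1ccccc1)SCC2)Nc1ccc(-c2ccsc2)cn1` gives 2 nM. Compound 3 `COc1ccc(-n2nc(C(=O)NCC(=O)Nc3nc4ccc(Cl)cc4s3)c3ccccc3c2=O)cc1` gives 15 nM. Among the numbers shown, compound 2 has the lowest, and its gap to compound 3 lies beyond the usual scatter. Compound 4 `O=C(CSc1nc2c(c(=O)n1-c1ccccc1)SCC2)Nc1ccc(-c2ccco2)cn1` differs from compound 2 in one place: furan-2-yl in place of thiophen-3-yl on an aromatic carbon. Among the compounds with values here, no measured step of this kind is available, so the expectation rests on the structural change alone. The step of a 2.0-fold higher number from compound 2 to compound 4 (0.30 log units; within the scatter) is expected to be small, toward slightly more compound needed. Compound 4 is therefore expected to give about 4 nM in this assay, within a range from 1.5 nM to 12 nM.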

Compound 4, half-maximal effective concentration: 3.5 nM
Estimate against measurement, compound 4: 1.1-fold (0.06 log units) above, and the stated range covers the measured number.
By their numbers in this assay, from the lowest: compounds 2 and 4 (each within the scatter of the next); then compound 3. At a limit, above all of these: compound 1.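

In this assay, within the data shown here, the swap of thiophen-3-yl for furan-2-yl gives a 1.8-fold higher number from compound 2 to compound 4 (0.24 log units; within the scatter), the only step measured at this place. For this pair, then, a ring oxygen in place of a ring sulfur, with the ring attached differently, leaves the number within the scatter. Nothing measured here explains why the step is this small. Still open, from the compounds shown here alone, is whether this place would tolerate something other than a five-membered aromatic ring, such as an amine or a carboxylic acid. Thiophen-2-yl and furan-3-yl are also absent, so the change of ring atom cannot be separated from the change of attachment.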